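Adding a second chloro to the urea aryl of compound 3

A few compounds are considered here, and "the series" means these few. Any claim that something is new, unique, unknown or untested is made for them only; others in the source may bear on it.

Measured compounds in a functional assay on MKN-45 cells (Homo sapiens) for cytotoxicity, read by MTT assay, with a stated time of 72 h; on this read-out higher numbers stand for weaker inhibition and lower numbers for stronger inhibition:
compound 1 `CN(C)CCNc1nc(-c2ccc(NC(=O)Nc3ccc(Cl)cc3Cl)cc2)nc2c(Cl)c(Cl)sc12`: 3460 nM
compound 2 `CCN(CC)CCCNc1nc(-c2ccc(NC(=O)Nc3ccc(F)cc3)cc2)nc2c(Cl)c(Cl)sc12`: 1700 nM
compound 3 `CCN(CC)CCCNc1nc(-c2ccc(NC(=O)Nc3ccccc3Cl)cc2)nc2c(Cl)c(Cl)sc12`: 1450 nM

Compound 3 gives the lowest of the three numbers, but its neighbour compound 2 lies within the scatter of it, so no order between the two can be drawn; only compound 1 stands apart, beyond the scatter. Among the compounds with values here, the one single-point step in this set, a 1.2-fold lower number from compound 2 to compound 3 (0.07 log units; within the scatter), is small.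

Compound 4 `CCN(CC)CCCNc1nc(-c2ccc(NC(=O)Nc3ccc(Cl)cc3Cl)cc2)nc2c(Cl)c(Cl)sc12` arises from compound 3 by chloro in place of hydrogen on an aromatic carbon. Within the data shown here, no measured step covers this exact change. Compound 1 carries the same 2,4-dichlorophenyl group, yet it also differs from compound 3 in the amine side chain, so its higher value cannot be assigned to the added chloro alone; it only hints that the number may rise. The expectation for compound 4 is therefore a modest increase, a 1.5-fold higher number from compound 3 to compound 4 (0.18 log units; within the scatter), possibly within the scatter. Compound 4 is estimated at 2200 nM, with a range of 1000 nM to 5000 nM.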

Compound 4, half-maximal inhibitory concentration: 5720 nM
Beside the measured number, compound 4's estimate is 2.6-fold (0.41 log units) below it; measured number outside the range, above it.
By their numbers in this assay, from the lowest: compounds 3 and 2 (each within the scatter of the next); then compounds 1 and 4 (each within the scatter of the next).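

In this assay the chloro that enters para to a large group and meta to a chloro group gives a 3.9-fold higher number from compound 3 to compound 4 (0.60 log units; beyond the scatter) and thus shows that this position on the urea aryl ring can shift the number beyond the scatter. The 2,4-dichlorophenyl group also stands apart from 4-fluorophenyl, with a 3.4-fold higher number from compound 2 to compound 4 (0.53 log units; beyond the scatter) as the step, while the change in the amine side chain gives a 1.7-fold higher number from compound 1 to compound 4 (0.22 log units; within the scatter) and so shows no readable difference with this aryl group in place. Nothing measured here gives a reason for the rise.

Going by these compounds, it stays open whether a methyl or a methoxy group at this place would raise the number as chloro does. Also open, on these data alone, is how a 4-chlorophenyl group, with no second chloro, would compare.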